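The source may hold more compounds than are shown below. What is called first, only, known or untested is meant among the compounds shown, and "the series" means these compounds.

Measured so far:
Compound 1, `Cn1nnnc1SCC(=O)N/N=c1/scc(-c2ccccc2)n1-c1ccccc1`, in an ADME assay on NIH3T3 cells (Mus musculus) for cytotoxicity, read by MTT assay, with a stated time of 24 h (a lower number here means a stronger inhibitor, a higher number a weaker inhibitor), gives 173 ug/mL.
Compound 2, `Cn1nnnc1SCC(=O)N/N=c1/scc(-c2ccc([N+](=O)[O-])cc2)n1-c1ccccc1`, in this assay gives 167 ug/mL.
Compound 3, `O=C(CSc1nnnn1-c1ccccc1)N/N=c1/scc(-c2ccc([N+](=O)[O-])cc2)n1-c1ccccc1`, in this assay gives 14.3 ug/mL.

Compound 2 stands second highest of the three numbers. Its nearest neighbour is compound 1, with the step of a 1.0-fold lower number from compound 1 to compound 2 (0.02 log units; within the scatter) lying within the scatter, so the two cannot be ordered. Compound 3 sits far apart, as the step of a 12-fold lower number from compound 2 to compound 3 (1.07 log units; beyond the scatter) shows; that step changed the group on an aromatic nitrogen and says nothing about the phenyl ring.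

Compound 4, `Cn1nnnc1SCC(=O)N/N=c1/scc(-c2ccc(Br)cc2)n1-c1ccccc1`, has not yet been measured in this assay. It differs from compound 2 in one place: bromo in place of nitro on an aromatic carbon. Of the measured steps only a 1.0-fold lower number from compound 1 to compound 2 (0.02 log units; within the scatter) touches the same aromatic carbon, and it stayed within the scatter. For the measured compounds named here, no measured step exchanges one group for another at that carbon, so there is no direct precedent for bromo against nitro. The working expectation is therefore a step of a 1.0-fold lower number from compound 2 to compound 4 (0.02 log units; within the scatter), that is, nothing beyond the scatter. Compound 4 is estimated at 160 ug/mL, with a range from 80 ug/mL to 320 ug/mL.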

Compound 4, half-maximal inhibitory concentration: 19.3 ug/mL
Beside the measured number, compound 4's estimate is 8.3-fold (0.92 log units) above it, and the stated range ends above it.
By their numbers in this assay, from the lowest: compounds 3 and 4 (each within the scatter of the next); then compounds 2 and 1 (each within the scatter of the next).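

In this assay the aromatic carbon carrying the substituent is not indifferent to what sits on it: the 4-nitrophenyl to 4-bromophenyl change gives an 8.7-fold lower number from compound 2 to compound 4 (0.94 log units; beyond the scatter), and bromo in place of hydrogen gives a 9.0-fold lower number from compound 1 to compound 4 (0.95 log units; beyond the scatter), whereas nitro in place of hydrogen gave only a 1.0-fold lower number from compound 1 to compound 2 (0.02 log units; within the scatter). For the compounds shown here, the flat result at this carbon therefore holds for hydrogen and nitro alone, and bromo is the one group of the three that separates from the others, with both of its steps beyond the scatter. No measurement offered here bears on why bromo differs from nitro and hydrogen at this carbon.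

As far as these compounds go, whether the lower number is particular to bromo or extends to chloro, fluoro, methoxy or an amine at the same carbon remains open. Also open, from the compounds shown here alone, is how the phenyl exchange on the aromatic nitrogen, seen so far only with the 4-nitrophenyl group as a 12-fold lower number from compound 2 to compound 3 (1.07 log units; beyond the scatter), would behave alongside the 4-bromophenyl group, and whether the two changes would add up or overlap.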